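This account rests on a few compounds, and the source may have more. Where it says the series, first, only, none or still open, it means among the compounds named here.

For the measured compounds named here, compound 2 `Fc1ccc(C2(c3ccc(F)cc3)CNC(c3ccsc3)=N2)cc1` gives the higher of the two numbers measured so far in an assay on LM cells for displacement of a labelled ligand from Neuropeptide Y receptor type 5 (Homo sapiens) (on this read-out lower numbers stand for stronger inhibition and higher numbers for weaker inhibition), namely 93 nM; the only other compound, compound 1 `N#Cc1cccc(C2=NC(c3ccc(F)cc3)(c3ccc(F)cc3)CN2)c1`, gives 2.7 nM in this assay. Going by the values given here, the one step between them, a 34-fold higher number from compound 1 to compound 2 (1.54 log units; beyond the scatter), shows that the group on the carbon with a double bond to nitrogen governs the read-out strongly. Compound 3 `Fc1ccc(C2(c3ccc(F)cc3)CNC(c3ccccn3)=N2)cc1` differs from compound 2 in the same place: pyridin-2-yl in place of thiophen-3-yl on a carbon with a double bond to nitrogen. Among the compounds with values here, no step between a thiophen-3-yl and a pyridin-2-yl group has been measured here, but the step from compound 1 to compound 2 shows that a six-membered aromatic ring at this carbon can give a far lower number than the thiophen-3-yl group. Compound 3 is therefore expected to show a 3.1-fold lower number from compound 2 to compound 3 (0.49 log units; beyond the scatter), an estimate that carries wide uncertainty. Compound 3 is estimated at 30 nM, with a range from 5 nM to 150 nM.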

Compound 3, half-maximal inhibitory concentration: 160 nM
Compound 3: the middle estimate sits 5.3-fold (0.73 log units) below what was measured; the measured number lies above the stated range.
By their numbers in this assay, from the lowest: compound 1; then compounds 2 and 3 (each within the scatter of the next).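

In this assay, pyridin-2-yl in place of thiophen-3-yl on the carbon with a double bond to nitrogen gives a 1.7-fold higher number from compound 2 to compound 3 (0.24 log units; within the scatter) and so does not separate these two rings at this position. A six-membered aromatic ring at this carbon is therefore not enough for a low number: pyridin-2-yl in place of 3-cyanophenyl gives a 59-fold higher number from compound 1 to compound 3 (1.77 log units; beyond the scatter) and leaves compound 1 clearly apart from compound 3.

The compounds shown leave open whether the low number of compound 1 depends on the nitrile of its 3-cyanophenyl group or on the phenyl ring that carries it. An unsubstituted phenyl ring, a pyridin-3-yl ring or a phenyl ring bearing a methoxy group at this carbon could help to separate the two. Nothing measured here explains the pattern at this position.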